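Amine swap carried from one core to its rearranged partner

The source may report more compounds than this note shows. Statements on the series, on what has been measured and on what is new or still open speak of the compounds shown alone.

Compound 1 `O=S(=O)(c1ccccc1)n1ccc2cc(N3CCCCC3)ccc21` and compound 3 `O=S(=O)(c1ccccc1)n1ccc2ccc(N3CCCCC3)cc21` share the same atoms joined differently; the difference between the two cores is not broken down here. In an assay on isolated protein for displacement of a labelled ligand from 5-hydroxytryptamine receptor 6 (Homo sapiens), read by scintillation counting, with a stated time of 1 h (a higher number here means a weaker inhibitor, a lower number a stronger inhibitor), compound 1 gives 360 nM, and compound 3 gives 403 nM, two numbers that sit within the usual scatter of each other. Compound 2 `CN(C)c1ccc2c(ccn2S(=O)(=O)c2ccccc2)c1` is made from compound 1 by dimethylamino in place of piperidin-1-yl on an aromatic carbon, and the step is a 4.4-fold lower number from compound 1 to compound 2 (0.64 log units; beyond the scatter); in this assay compound 2 gives 82 nM. Compound 4 `CN(C)c1ccc2ccn(S(=O)(=O)c3ccccc3)c2c1` applies the same change to the core of compound 3: dimethylamino in place of piperidin-1-yl on an aromatic carbon. The description of the place is the same word for word in both cases, so this is the same change, carried onto the other core, and it occurs twice among the compounds shown. For the measured compounds named here, the step expected here is a 4.0-fold lower number from compound 3 to compound 4 (0.61 log units; beyond the scatter), which rests on the single measured instance, a 4.4-fold lower number from compound 1 to compound 2 (0.64 log units; beyond the scatter), and on compound 3 starting at 403 nM. Compound 4 is therefore estimated at 100 nM in this assay, with a range expected between 40 nM and 250 nM.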

Compound 4, inhibition constant: 211 nM
Beside the measured number, compound 4's estimate is 2.1-fold (0.32 log units) below it, within the range that was stated.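

In this assay, dimethylamino in place of piperidin-1-yl on the core of compound 3 gives a 1.9-fold lower number from compound 3 to compound 4 (0.28 log units; within the scatter), whereas on the core of compound 1 the same change gives a 4.4-fold lower number from compound 1 to compound 2 (0.64 log units; beyond the scatter). For the compounds shown here, only the step on the core of compound 1 lies beyond the scatter, yet the two steps cannot be told apart: the same change on two cores in this assay, a 4.4-fold lower number (0.64 log units; beyond the scatter) from compound 1 to compound 2 and a 1.9-fold lower number (0.28 log units; within the scatter) from compound 3 to compound 4, 2.3-fold (0.36 log units) apart, within the scatter of two such steps. This gives no ground for calling the effect of the change dependent on the core, but with one pair per core it does not show that the step carries over at full size, nor that a real step exists on the core of compound 3.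

The compounds shown leave open whether other cyclic amines, such as pyrrolidin-1-yl or morpholin-4-yl, would track piperidin-1-yl on both cores. Also open, as far as these compounds go, is whether an acyclic amine with longer chains, such as diethylamino, would stay with dimethylamino on both cores.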